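A few compounds are considered here, and "the series" means these few. Any claim that something is new, unique, unknown or untested is made for them only; others in the source may bear on it.

Of the compounds shown here, three have so far been measured in an assay for inhibition of beta-galactosidase (Bos taurus), read by spectrophotometry; a lower number here means a stronger inhibitor, a higher number a weaker inhibitor. Compound 1 `CCCC/N=C1/SC[C@H]2[C@H](O)[C@@H](O)[C@H](CO)N12` gives 719000 nM in this assay, the highest of the three numbers. Compound 2 `CCCCCCCCCCCC/N=C1/SC[C@@H]2[C@@H](O)[C@H](O)[C@@H](CO)N12` carries a dodecyl chain on the imine nitrogen and differs from compound 1 in several places; in this assay compound 2 gives 32000 nM, and that gap lies beyond the usual scatter. Compound 3 `CCCCCCCCCCCCNC(=S)N1[C@H](CO)[C@@H](O)[C@H](O)[C@H]1CO`, a thiourea with the same dodecyl chain, gives 24000 nM in this assay, the lowest of the three and again beyond the scatter from compound 1. No two of these compounds differ in a single place, so no single step can be read off.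

Compound 4 `CCCCCCCCCC/N=C1/SC[C@H]2[C@H](O)[C@@H](O)[C@H](CO)N12` has not yet been measured. It differs from compound 1 by one change: hexyl in place of hydrogen on a saturated chain carbon, four bonds along the chain from a double-bonded nitrogen. The chain on the imine nitrogen thus grows from butyl to decyl while the core of compound 1 is kept.

Since compound 2 with its longer chain gives 32000 nM against compound 1 with 719000 nM, a step in the direction of a lower number is expected for compound 4, well beyond the scatter. The step from compound 1 to compound 4 is estimated at a 16-fold lower number from compound 1 to compound 4 (1.20 log units; beyond the scatter). Compound 4 is therefore expected to give about 45000 nM in this assay, within a range from 12000 nM to 170000 nM.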

Compound 4, half-maximal inhibitory concentration: 36000 nM
Beside the measured number, compound 4's estimate is 1.3-fold (0.10 log units) above it; measured number inside the range.
By their numbers in this assay, from the lowest: compounds 3, 2 and 4 (each within the scatter of the next); then compound 1.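

With the core of compound 1 held fixed, hexyl in place of hydrogen on a saturated chain carbon, four bonds along the chain from a double-bonded nitrogen, gives a 20-fold lower number from compound 1 to compound 4 (1.30 log units; beyond the scatter) in this assay, a large step. The earlier compounds shown here differed from one another in several places, so none could tie a change in the number to this chain alone; this pair shows that this position responds strongly to the change by itself, and the group that enters has 6 heavy atoms, all carbon, with no ring and no hydrogen-bond donors or acceptors. Nothing measured here bears on what lies behind the step.

The compounds shown leave open how the number runs with chain length on this core, since only butyl and decyl chains stand on it, and an octyl or a dodecyl chain there would fill in that picture. They also leave open whether a chain holding an amine or a phenyl ring would give a step of similar size.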